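Trading a Selenium Chain for an Amino Group

This account rests on a few compounds, and the source may have more. Where it says the series, first, only, none or still open, it means among the compounds named here.

Compound 1 `CCCCC[Se]c1nc([Se]CCCCC)c2ccccc2n1` was tested in an ADME assay on BEAS-2B cells (Homo sapiens) for cytotoxicity, read by MTT assay, with a stated time of 72 h; a lower number here means a stronger inhibitor of growth, a higher number a weaker inhibitor of growth. In this assay compound 1 gives > 100000 nM, which is a limit of the assay rather than a number. Compound 2 `C[Se]c1nc([Se]C)c2ccccc2n1` belongs to the same series, but in this assay compound 2 gives "not determined" (no result reported). Compound 1 therefore stands at the limit of > 100000 nM in this assay, at which 1 of the 2 values shown sits, and no single number is available for any compound in the set.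

Compound 3 `CCCCC[Se]c1nc(N)c2ccccc2n1` has not yet been measured in this assay. It differs from compound 1 in one place: one nitrogen atom in place of a group of 6 heavy atoms (5 carbon, 1 selenium; no ring), on an aromatic carbon, in words, one nitrogen atom in place of a group of 6 heavy atoms (5 carbon, 1 selenium; no ring), on an aromatic carbon.

For the measured compounds named here, no step between measured compounds exists, so nothing here anchors the size of this change. With compound 1 resting at a limit, the expected step is a number no higher from compound 1 to compound 3 (the limit leaves the size open), none beyond the scatter. Compound 3 is estimated at about 100000 nM in this assay. Compound 3 is expected to fall between 30000 nM and 300000 nM, with a good chance that the assay again reports only a limit.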

Compound 3, concentration for 50% growth inhibition: 52300 nM
Beside the measured number, compound 3's estimate is 1.9-fold (0.28 log units) above it; the range from low to high includes it.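

In this assay, replacing a group of 6 heavy atoms with amino at this position, on an aromatic carbon next to the ring nitrogen, gives an at least 1.9-fold lower number from compound 1 to compound 3 (0.28 log units; that floor lies within the scatter). For the compounds shown here, this is the first look at a change at this position, and compound 3, at 52300 nM, is the only compound in the set with a single number, so the exchange brings the read-out to a value the assay can report. The size of the step still has only a floor, and compound 1 remains a limit of the assay rather than a number: the limit of > 100000 nM in this assay, at which 1 of the 3 values shown sits.

The compounds shown leave open whether the result follows from the arrival of the amino group or simply from the loss of the selenium-bearing chain, a question that a methoxy group, a dimethylamino group or a shorter selenium chain at the same position could help to separate. They also leave open how the second group of 6 heavy atoms on the shared core contributes, and whether an amino group in that place as well would give a lower number still.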